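This account rests on a few compounds, and the source may have more. Where it says the series, first, only, none or still open, it means among the compounds named here.

Series notes. In an ADME assay on HepG2 cells (Homo sapiens) for cytotoxicity, read by sulforhodamine B assay, with a stated time of 48 h (on this read-out lower numbers stand for higher toxicity in this test and higher numbers for lower toxicity in this test), compound 1 `COc1nc2ccccc2cc1/C=C/c1noc(-c2ccc(C)cc2)n1` gives > 230000 nM, which is a limit of the assay and not a number. Compound 2 `COc1cccc(-c2nc(/C=C/c3cc4ccccc4nc3OC)no2)c1` likewise reaches only a limit, > 220000 nM. Compound 3 `COc1nc2ccccc2cc1/C=C/c1noc(-c2cccc(Cl)c2)n1` also stops at a limit, > 220000 nM. Compound 3 thus stands at the limit of > 220000 nM in this assay, at which 2 of the 3 values shown sit. Compound 1 stands at the limit of > 230000 nM in this assay, at which 1 of the 3 values shown sits. The measured steps a step that the two limits leave unreadable from compound 1 to compound 2, a step that the two limits leave unreadable from compound 1 to compound 3 and a step that the two limits leave unreadable from compound 2 to compound 3 yield no size; both ends of each are limits. Compound 4 `COc1nc2ccccc2cc1/C=C/c1noc(-c2cccnc2)n1` differs from compound 3 by pyridin-3-yl in place of 3-chlorophenyl on an aromatic carbon. Going by the values given here, no measured step covers this change, and none of the three values bounds its direction. In this assay compound 4 is expected again at a limit, estimated as 220000 nM with range 100000 nM to 300000 nM. The expected step of a number no higher from compound 3 to compound 4 (the limit leaves the size open) is none beyond the scatter.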

Compound 4, half-maximal cytotoxic concentration: > 240000 nM
Compound 4 gave a limit, no number; the forecaster's own chance of this, stated with the estimate: 85%; middle value at least 1.0-fold (0.03 log units) away from the limit.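

Compound 4 stops at a limit, as do compound 1, compound 2 and compound 3, so no step among these four compounds can be read. The compounds shown leave open whether any of these group changes on the shared core alters the read-out in this assay at all.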